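Swapping cyano for trifluoromethyl on compound 3

The source may hold more compounds than are shown below. What is called first, only, known or untested is meant among the compounds shown, and "the series" means these compounds.

In a functional assay on SU-DHL-6 cells (Homo sapiens) for antiproliferative activity, read by MTT assay (a lower number here means a stronger inhibitor, a higher number a weaker inhibitor), compound 1 (`COc1ncc(-c2ccc3ncnc(N[C@H]4CCCN(C(=O)C(F)(F)F)C4)c3c2)cc1C#N`) gives 210 nM, compound 2 (`COc1ncc(-c2ccc3ncnc(N[C@H]4CCCN(C(=O)C5CCN(C)CC5)C4)c3c2)cc1C#N`) gives 420 nM and compound 3 (`CCOC(=O)CN1CCC[C@H](Nc2ncnc3ccc(-c4cnc(OC)c(C#N)c4)cc23)C1`) gives 500 nM. Two steps place compound 3 among them: there is a 2.4-fold higher number from compound 1 to compound 3 (0.38 log units; beyond the scatter), and there is a 1.2-fold higher number from compound 2 to compound 3 (0.08 log units; within the scatter). These steps, like a 2.0-fold higher number from compound 1 to compound 2 (0.30 log units; within the scatter), all change the group on an amine nitrogen in a ring.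

Compound 4 (`CCOC(=O)CN1CCC[C@H](Nc2ncnc3ccc(-c4cnc(OC)c(C(F)(F)F)c4)cc23)C1`) keeps the (ethoxycarbonyl)methyl group of compound 3 and changes a different place, with trifluoromethyl in place of cyano on an aromatic carbon. Among the measured compounds shown here, no measured compound varies that place, so none of the measured steps bears directly on this change, and the data offer no direction for it. For the measured compounds named here, the only anchor is compound 3 at 500 nM, so no step beyond the scatter is expected in this assay, though with wide uncertainty. The expected change is a 1.2-fold higher number from compound 3 to compound 4 (0.08 log units; within the scatter). For compound 4 the estimated value is 600 nM, with an expected range from 200 nM to 1800 nM.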

Compound 4, half-maximal inhibitory concentration: 230 nM
The estimate for compound 4 lay 2.6-fold (0.42 log units) above the measured number; measured number inside the range.
By their numbers in this assay, from the lowest: compounds 1, 4, 2 and 3 (each within the scatter of the next, the first and the last beyond it).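

In this assay trifluoromethyl in place of cyano gives a 2.2-fold lower number from compound 3 to compound 4 (0.34 log units; beyond the scatter) and is the only step shown at this aromatic carbon, ortho to a methoxy group. Earlier steps all changed the group on the ring amine nitrogen, so this one shows that the number also responds to a change at this second place. The cyano counts one hydrogen-bond acceptor and the trifluoromethyl none, so in compound 4 activity in this assay does not depend on an acceptor in the group at this carbon, and nothing shown accounts for the shift.

Still open, going by these compounds, is how a chlorine atom, a methyl group or a primary amide would read at this carbon. Also open, on these data alone, is whether the same swap gives a similar step when the ring amine nitrogen carries the (1-methylpiperidin-4-yl)carbonyl group of compound 2.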